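From 2-fluoro-6-methylbenzyl to cyclopropylmethyl on a shared core

The compounds below may be only part of what the source reports. "The series", "measured", "known", "first", "only" and "open" are said of these compounds alone.

Among the compounds with values here, only two compounds have been measured so far. In an ADME assay on microsomes from liver (Mus musculus) for metabolic stability, with a stated time of 10 min (a higher number here means that more of the compound is left, a lower number that less of the compound is left), compound 1 (`O=C(O)C1CCN(C(=O)N2CC[C@](c3ccc(C(OCc4c(F)cccc4F)(C(F)(F)F)C(F)(F)F)cc3)(S(=O)(=O)c3ccc(F)cc3)C2)CC1`) stands at 84% and compound 2 (`Cc1cccc(F)c1COC(c1ccc([C@]2(S(=O)(=O)c3ccc(F)cc3)CCN(C(=O)[C@H]3CC[C@H](C(=O)O)CC3)C2)cc1)(C(F)(F)F)C(F)(F)F`) stands at 78% after the incubation. These two numbers lie within the usual scatter of each other, so compound 2 cannot be ranked apart from compound 1.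

Compound 3 (`O=C(O)[C@H]1CC[C@H](C(=O)N2CC[C@](c3ccc(C(OCC4CC4)(C(F)(F)F)C(F)(F)F)cc3)(S(=O)(=O)c3ccc(F)cc3)C2)CC1`) departs from compound 2 in one place: cyclopropyl in place of 2-fluoro-6-methylphenyl on a saturated chain carbon bound to an oxygen on a saturated carbon in the structure. Cyclopropyl replaces 2-fluoro-6-methylphenyl on a saturated chain carbon bound to an oxygen on a saturated carbon. Cut one bond further out, the change reads 2-fluoro-6-methylbenzyl to cyclopropylmethyl.

Within the data shown here, no two measured compounds differ in one place only, so no measured step can guide this change. The expectation starts from compound 2 at 78% in this assay and allows for a large uncertainty. A small downward move is expected, with a number 6 percentage points lower from compound 2 to compound 3 (within the scatter) as the estimated step, and that would stay within the scatter. For compound 3 the estimated value is 72% within an expected range of 52% to 90% in this measurement.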

Compound 3, percent of the compound remaining: 44%
The estimate for compound 3 lay 28 percentage points above the measured number; measured number below the stated range.
By their numbers in this assay, from the lowest: compound 3; then compounds 2 and 1 (each within the scatter of the next).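

Within the data shown here, this is the first reading of a change at one place: in this assay, exchanging 2-fluoro-6-methylbenzyl for cyclopropylmethyl gives a number 34 percentage points lower from compound 2 to compound 3 (beyond the scatter), a large step beyond the scatter that shows the number can depend strongly on the group at this position. Compound 1 and compound 2 differ in more than one place and lie within the scatter of each other, so they gave no reading of this position on its own. Nothing at hand bears on the reason for this step.

The step replaces a six-membered aromatic ring carrying fluorine and methyl with a three-membered non-aromatic ring, and the compounds shown do not separate the aromatic ring, the ring size, the fluorine or the methyl from one another. Also open, from the compounds shown here alone, is where a plain benzyl group or a straight butyl chain on the same oxygen would fall in this assay, and whether the step would be of similar size on the shared core of compound 1.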